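Swapping a chloro for a methyl on the benzyl ring

This account rests on a few compounds, and the source may have more. Where it says the series, first, only, none or still open, it means among the compounds named here.

Compound 3 `COc1ccc([C@@H]2CC(=O)c3c(O)cc(OCc4cn(Cc5ccc(Cl)cc5)nn4)cc3O2)cc1O` carries a 4-chlorophenyl on a saturated chain carbon bound to an aromatic nitrogen. In a functional assay on RAW264.7 cells (Mus musculus) for inhibition, read by Griess assay, with stated times of 2 h and 24 h (a higher number here means a weaker inhibitor, a lower number a stronger inhibitor), compound 3 gives 17800 nM, the second highest of three numbers. Compound 2 `COc1ccc([C@@H]2CC(=O)c3c(O)cc(OCc4cn(Cc5cccc(C(F)(F)F)c5)nn4)cc3O2)cc1O` gives 19900 nM, and the gap a 1.1-fold lower number from compound 2 to compound 3 (0.05 log units; within the scatter) says the two are indistinguishable. Compound 1 `COc1ccc([C@@H]2CC(=O)c3c(O)cc(OCc4cn(Cc5ccccc5Cl)nn4)cc3O2)cc1O` gives 6140 nM, and the steps of a 2.9-fold higher number from compound 1 to compound 3 (0.46 log units; beyond the scatter) and a 3.2-fold higher number from compound 1 to compound 2 (0.51 log units; beyond the scatter) show that compound 1 is the stronger inhibitor of the three.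

Compound 4 `COc1ccc([C@@H]2CC(=O)c3c(O)cc(OCc4cn(Cc5ccc(C)cc5)nn4)cc3O2)cc1O` differs from compound 3 by methyl in place of chloro on an aromatic carbon. Going by the values given here, no measured step makes this exact exchange, so nothing directly tells its size. The closest guide is a 1.1-fold lower number from compound 2 to compound 3 (0.05 log units; within the scatter), where exchanging one substituted benzyl for another at the same saturated chain carbon changed nothing beyond the scatter. A step of the same kind is therefore expected: a 1.0-fold higher number from compound 3 to compound 4 (0.00 log units; within the scatter), with no clear direction. Compound 4 is estimated at 18000 nM, most likely between 8000 nM and 40000 nM.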

Compound 4, half-maximal inhibitory concentration: 16800 nM
Estimate against measurement, compound 4: 1.1-fold (0.03 log units) above; the measured number falls inside the stated range.
By their numbers in this assay, from the lowest: compound 1; then compounds 4, 3 and 2 (each within the scatter of the next).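

In this assay, methyl and chloro cannot be told apart at this position, para to a large group (a 1.1-fold lower number from compound 3 to compound 4 (0.03 log units; within the scatter)). The 4-methylphenyl of compound 4 also matches the 3-(trifluoromethyl)phenyl of compound 2 within the scatter (a 1.2-fold lower number from compound 2 to compound 4 (0.07 log units; within the scatter)), while compound 1, with its 2-chlorophenyl, remains the stronger inhibitor (a 2.7-fold higher number from compound 1 to compound 4 (0.44 log units; beyond the scatter)), so compounds 2, 3 and 4 now form a cluster that compound 1 stands apart from. Nothing measured here explains why the exchange of chloro for methyl leaves the number so little changed, or why compound 1 differs from the others.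

Still open, going by these compounds, is whether a different group at this position, such as an amine or a carboxylic acid, would move the number at all. It is also unknown whether methyl would match chloro on the ring of compound 1 as it does on the ring of compound 3.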